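Aryl exchange at the saturated ring carbon: compound 2 to compound 4

This account rests on a few compounds, and the source may have more. Where it says the series, first, only, none or still open, it means among the compounds named here.

Of the compounds shown here, three sharing one core have been measured in an ADME assay on Vero cells (Chlorocebus sabaeus) for cytotoxicity, read by neutral red uptake, tested at 3150 ug/mL; on this read-out lower numbers stand for a stronger effect and higher numbers for a weaker effect at the one concentration tested. Compound 1 `O=C1CSC(c2c(Cl)cccc2Cl)N1CCN1CCCCC1` gives 7%. Compound 2 `O=C1CSC(c2cccc(O)c2)N1CCN1CCCCC1` gives 11%. Compound 3 `COc1ccccc1C1SCC(=O)N1CCN1CCCCC1` gives 5%. Compound 2 is the reference for the step considered here; its number sits with that of compound 1 and with that of compound 3 inside the usual scatter of this read-out, so the three are not separated from one another on the numbers shown. Within the data shown here, no pair among them differs in just one place, so no single-point step is available as a guide to what an exchange of the aromatic group does.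

Compound 4 `O=C1CSC(c2ccc(F)cc2)N1CCN1CCCCC1` is the compound not yet measured. Against compound 2 it carries 4-fluorophenyl in place of 3-hydroxyphenyl on a saturated ring carbon. The change is an exchange of one aromatic ring for another at the same saturated ring carbon, and the three measured compounds with differing aromatic rings all lie together; on that basis the expected step of a number 3 percentage points lower from compound 2 to compound 4 (within the scatter) in this assay is none beyond the scatter. Compound 4 is accordingly estimated at 8% in this assay, with a range from 2% to 16%.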

Compound 4, a percentage reported as activity, at one concentration (the size of the read-out at that concentration, not a potency): 11%
Estimate against measurement, compound 4: 3 percentage points below; low and high end bracket the measured number.
By their numbers in this assay, from the lowest: compounds 3, 1, 2 and 4 (each within the scatter of the next).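

Among these compounds, this is the first step that differs in one place, and at the saturated ring carbon it gives no change at the digits printed from compound 2 to compound 4 (within the scatter) in this assay. The hydrogen-bond donor and acceptor counted on 3-hydroxyphenyl are absent from 4-fluorophenyl, and the fluorine now present on the aromatic ring is likewise accompanied by no step beyond the scatter, so for this one pair the read-out at the single concentration tested does not separate the two aromatic groups. No supporting measurement is available to explain this result.

All four compounds carry a six-membered aromatic ring at this carbon, which leaves open whether a carboxylic acid or an aminomethyl group on that ring, or a cyclohexyl group in its place, would give a step beyond the scatter. The group of 8 heavy atoms is the same throughout, so the compounds shown give no step for a change there, such as a longer chain.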